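A few compounds are considered here, and "the series" means these few. Any claim that something is new, unique, unknown or untested is made for them only; others in the source may bear on it.

Measured compounds:
- compound 1, `COc1ncc(-c2ccccc2)cc1[C@@H](c1ccccc1)[C@@](O)(CCN(C)C)c1cccc(F)c1F`, cytotoxicity value known
- compound 2, `COc1nc(-c2ccccc2F)ccc1[C@@H](c1ccccc1)[C@@](O)(CCN(C)C)c1cccc2ccccc12`, no result reported

In a toxicity assay on HeLa cells (Homo sapiens) for cytotoxicity (on this read-out higher numbers stand for lower toxicity in this test and lower numbers for higher toxicity in this test), compound 1 gives 28.1 ug/mL. For compound 2 the entry in this assay reads "nd" (no result reported), so no number exists; compound 2 therefore stands nowhere on the read-out shown, and compound 1 is the only measured point in the series. Compound 3, `COc1nc(C2CCCCC2)ccc1[C@@H](c1ccccc1)[C@@](O)(CCN(C)C)c1cccc2ccccc12`, is not yet measured. It differs from compound 2 in one place: cyclohexyl in place of 2-fluorophenyl on an aromatic carbon.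

Within the data shown here, no step between measured compounds has been recorded, so nothing in the data gives a size or direction for the change from compound 2 to compound 3 in this assay. With no value for compound 2, the step itself cannot be anchored; any expectation for compound 3 rests on compound 1 alone, which shares the same dimethylamino-alcohol arm and methoxy-substituted core but differs at several places, so it is a loose guide. The working expectation is that compound 3 will fall in the same broad range as compound 1, with no claim on direction beyond the scatter.

Compound 3 is estimated at 20 ug/mL in this assay, expected to lie between 7 ug/mL and 55 ug/mL.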

Compound 3, half-maximal cytotoxic concentration: 57.7 ug/mL
Beside the measured number, compound 3's estimate is 2.9-fold (0.46 log units) below it; the measured number lies above the stated range.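

Among these compounds, with compound 2 carrying no number in this assay, no step to compound 3 can be read, and compound 3 at 57.7 ug/mL stands without a matched partner. The compounds shown leave open how replacing 2-fluorophenyl with cyclohexyl shifts this read-out. No supporting data bear on this result.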